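A few compounds are considered here, and "the series" means these few. Any claim that something is new, unique, unknown or untested is made for them only; others in the source may bear on it.

Measured in a functional assay on HCT-15 cells (Homo sapiens) for antiproliferative activity, read by sulforhodamine B assay; a lower number here means a stronger inhibitor of growth, a higher number a weaker inhibitor of growth:
- Compound 1 `CCCCCCOc1cccc(O)c1C(=O)/C=C/c1ccc(O)cc1`: > 30000 nM, a limit
- Compound 2 `O=C(/C=C/c1ccc(O)cc1)c1c(O)cccc1OCCC1CCCCC1`: > 30000 nM, a limit
- Compound 3 `CC(C)COc1cccc(O)c1C(=O)/C=C/c1ccc(O)cc1`: 2600 nM

Compound 3 is the only one of the three with a number, and both steps to it are large: an at least 11-fold lower number from compound 1 to compound 3 (1.06 log units; beyond the scatter) and an at least 11-fold lower number from compound 2 to compound 3 (1.06 log units; beyond the scatter). Compound 4 `O=C(/C=C/c1ccc(O)cc1)c1c(O)cccc1OCCC1CCCC1` differs from it as follows: cyclopentylmethyl in place of isopropyl on a saturated chain carbon bound to an oxygen on an aromatic ring. Cyclopentylmethyl thus replaces isopropyl on a saturated chain carbon bound to an oxygen on an aromatic ring.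

Compound 2 carries cyclohexylmethyl at that place, so an at least 11-fold lower number from compound 2 to compound 3 (1.06 log units; beyond the scatter) bears most closely, read in reverse. A large rise in this assay is therefore expected, meaning weaker growth inhibition. The expected change is an 8.5-fold higher number from compound 3 to compound 4 (0.93 log units; beyond the scatter). For compound 4 the estimate is 22000 nM, with an expected range of 7000 nM to 60000 nM.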

Compound 4, concentration for 50% growth inhibition: 3310 nM
Estimate against measurement, compound 4: 6.6-fold (0.82 log units) above; the whole stated range lies above it.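

For the compounds shown here, at this place, on a saturated chain carbon bound to an oxygen on an aromatic ring, the bulkier count of cyclopentylmethyl need not cost growth inhibition in this assay, which the earlier compounds did not show: a 1.3-fold higher number from compound 3 to compound 4 (0.10 log units; within the scatter). The outcome turns on the end of the chain, with cyclopentyl in place of cyclohexyl giving an at least 9.0-fold lower number from compound 2 to compound 4 (0.95 log units; beyond the scatter) and cyclopentyl in place of butyl giving an at least 9.0-fold lower number from compound 1 to compound 4 (0.95 log units; beyond the scatter). Both of these steps start from a limit and not a number: the limit of > 30000 nM in this assay, at which 2 of the 4 values shown sit.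

As far as these compounds go, whether a cyclobutyl or phenyl ring on the same chain, or an amine there, would fit equally stays open.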